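Aryl ether variation in the shared core series

This account rests on a few compounds, and the source may have more. Where it says the series, first, only, none or still open, it means among the compounds named here.

Three members of the series are in hand. Compound 1 `Cc1nn(C)c(Oc2cccc(Cl)c2)c1/C=N\CCCCCCOc1cc2oc(=O)cc(C)c2cc1Cl` gives 6220 nM in a functional assay on HepG2 cells (Homo sapiens) for antiproliferative activity, read by MTT assay, with a stated time of 72 h; on this read-out higher numbers stand for weaker inhibition and lower numbers for stronger inhibition. Compound 2 `Cc1nn(C)c(Oc2cccc(Br)c2)c1/C=N\CCCCCCOc1cc2oc(=O)cc(C)c2cc1Cl` gives 6830 nM in this assay, and the exchange of bromo for chloro reads a 1.1-fold higher number from compound 1 to compound 2 (0.04 log units; within the scatter). Compound 3 `Cc1ccc(Oc2c(/C=N\CCCCCCOc3cc4oc(=O)cc(C)c4cc3Cl)c(C)nn2C)cc1` gives 20700 nM, the highest of the three numbers; against compound 2 the gap is a 3.0-fold higher number from compound 2 to compound 3 (0.48 log units; beyond the scatter), against compound 1 it is a 3.3-fold higher number from compound 1 to compound 3 (0.52 log units; beyond the scatter), so compound 3 sits apart from both on the weaker side.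

Compound 4 `Cc1nn(C)c(Oc2cccc(C(F)(F)F)c2)c1/C=N\CCCCCCOc1cc2oc(=O)cc(C)c2cc1Cl` has not yet been run. From compound 3 the change is 3-(trifluoromethyl)phenyl in place of 4-methylphenyl on an oxygen on an aromatic ring. The two steps that bear on it, a 3.3-fold higher number from compound 1 to compound 3 (0.52 log units; beyond the scatter) and a 3.0-fold higher number from compound 2 to compound 3 (0.48 log units; beyond the scatter), both show that replacing a 3-substituted phenyl by 4-methylphenyl on the ring oxygen moved the number modestly upward. Going back to a 3-substituted phenyl, here 3-(trifluoromethyl)phenyl, is therefore expected to move the number downward by a comparable modest amount, roughly back to the level of compound 1 and compound 2, though the trifluoromethyl group itself has no precedent in the set and a step no larger than the scatter cannot be excluded. The expected step in this assay is a 3.0-fold lower number from compound 3 to compound 4 (0.47 log units; beyond the scatter). Compound 4 is estimated at 7000 nM, within a range of 3000 nM to 16000 nM.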

Compound 4, half-maximal inhibitory concentration: > 25000 nM
Compound 4 gave a limit, no number; the forecaster's own chance of this, stated with the estimate: 3%; middle value at least 3.5-fold (0.55 log units) away from the limit.
By their numbers in this assay, from the lowest: compounds 1 and 2 (each within the scatter of the next); then compound 3. At a limit, above all of these: compound 4.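

Compound 4 reads as a limit of the assay, not as a number: the limit of > 25000 nM in this assay, at which 1 of the 4 values shown sits. Among the compounds shown here, the group on this aromatic carbon now matters where the earlier compounds showed no separation: chloro and bromo read alike within the scatter, whereas trifluoromethyl in place of bromo gives an at least 3.6-fold higher number from compound 2 to compound 4 (0.56 log units; beyond the scatter), and trifluoromethyl in place of chloro gives an at least 4.0-fold higher number from compound 1 to compound 4 (0.60 log units; beyond the scatter), so 3-chlorophenyl and 3-bromophenyl do not speak for every such aryl ether. Against the 4-methylphenyl ether the reading is less firm, with an at least 1.2-fold higher number from compound 3 to compound 4 (0.08 log units; that floor lies within the scatter), a floor that leaves compound 3 and compound 4 unordered on the printed figures.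

Going by these compounds, how far compound 4 lies beyond its limit remains unknown, and with it the true size of all three steps, so these steps fix only a floor and not a trend across the aryl ethers. Also open, on these data alone, is whether the low end of this set is confined to chloro and bromo, or whether a methoxy group or an amine in place of chloro on the same aromatic carbon would stay at the level of compound 1 and compound 2.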